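The compounds below may be only part of what the source reports. "The series", "measured", "known", "first", "only" and "open" are said of these compounds alone.

Measured so far in a functional assay on L1210 cells (Mus musculus) for inhibition; on this read-out lower numbers stand for stronger inhibition and higher numbers for weaker inhibition:
- compound 1, `O=C1CCCCC/C1=C\c1ccccc1`, gives 261000 nM
- compound 2, `O=C1CCCCC/C1=C\c1cccc(F)c1`, gives 382000 nM

Within the data shown here, compound 1 has the lower of these two numbers, but its only neighbour, compound 2, sits just a step of a 1.5-fold higher number from compound 1 to compound 2 (0.17 log units; within the scatter) away, and that step is within the scatter, so the two compounds cannot be told apart on these numbers.

Compound 3, `O=C1CCCCC/C1=C\c1ccc(F)cc1`, is the next compound of interest. Compared with compound 1 the change is fluoro in place of hydrogen on an aromatic carbon. Among the measured compounds shown here, the one measured step that bears on this is the step from compound 1 to compound 2, which is the same kind of change, fluoro in place of hydrogen on an aromatic carbon, and it gave a 1.5-fold higher number from compound 1 to compound 2 (0.17 log units; within the scatter), a move within the scatter. Nothing in the data therefore points to a shift beyond the scatter here, and compound 3 is expected to land close to compound 1, with an estimated step of a 1.1-fold higher number from compound 1 to compound 3 (0.06 log units; within the scatter). The estimate for compound 3 is 300000 nM, with a range from 150000 nM to 600000 nM.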

Compound 3, half-maximal inhibitory concentration: 291000 nM
The estimate for compound 3 lay 1.0-fold (0.01 log units) above the measured number, and the stated range covers the measured number.
By their numbers in this assay, from the lowest: compounds 1, 3 and 2 (each within the scatter of the next).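

Putting fluoro on the aromatic carbon para to a group of 9 heavy atoms gives a 1.1-fold higher number from compound 1 to compound 3 (0.05 log units; within the scatter) in this assay, so at this position too, the swap of hydrogen for fluoro makes no change that can be read. Compound 2 carries its fluoro on a different carbon of the same aromatic ring and also stays within the scatter of compound 1, so neither fluoro placement shown separates a compound from compound 1. No supporting evidence is available to explain this result.

From the compounds shown here alone, it remains open whether a different group on this carbon, such as a methoxy group, an amine or a carboxylic acid, would move the number beyond the scatter. Going by these compounds, it is also open whether changes to the shared core outside the aromatic ring would have a larger effect in this assay.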